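Moving the Fluorine from 3-Fluorophenyl to 2-Fluorophenyl

The source may report more compounds than this note shows. Statements on the series, on what has been measured and on what is new or still open speak of the compounds shown alone.

In a functional assay on KB cells (Homo sapiens) for antiproliferative activity, read by sulforhodamine B assay, with a stated time of 3 days (a higher number here means that more compound is needed for the effect, a lower number that less compound is needed), compound 1 `CCC1=C(O)c2c(oc(-c3ccc(OC)cc3)cc2=O)C(CC)(CC)C1=O` gives 17.7 uM. Compound 2 `CCC1=C(O)c2c(oc(-c3ccc(SC)cc3)cc2=O)C(CC)(CC)C1=O` reads > 52.1 uM, which is a limit of the assay. Compound 3 `CCC1=C(O)c2c(oc(-c3cccc(F)c3)cc2=O)C(CC)(CC)C1=O` reads > 56.2 uM, which is also a limit and not a number. Compound 4 `CCC1=C(O)c2c(oc(-c3ccccc3F)cc2=O)C(CC)(CC)C1=O` carries 2-fluorophenyl in place of 3-fluorophenyl on an aromatic carbon. Two measured steps offer guidance: an at least 2.9-fold higher number from compound 1 to compound 2 (0.46 log units; beyond the scatter) and an at least 3.1-fold higher number from compound 1 to compound 3 (0.50 log units; beyond the scatter). The second bears more closely, but neither moves the fluorine, and a step that the two limits leave unreadable from compound 2 to compound 3 adds nothing. No change beyond the scatter is therefore expected in this assay, and the expected step is an at least 1.1-fold lower number from compound 3 to compound 4 (0.05 log units; that floor lies within the scatter). The estimate for compound 4 is 50 uM, with an expected range of 22 uM to 85 uM.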

Compound 4, concentration for half-maximal effect: > 56.2 uM
Compound 4 ended at the assay's limit (the forecaster's own chance of this, stated with the estimate: 70%); middle value at least 1.1-fold (0.05 log units) away from the limit.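

In this assay, moving the fluorine to 2-fluorophenyl leaves compound 4 at a limit of the assay, the same limit as compound 3: the limit of > 56.2 uM in this assay, at which 2 of the 4 values shown sit. Neither fluorine position matches the 4-methoxyphenyl group, with an at least 3.1-fold higher number from compound 1 to compound 4 (0.50 log units; beyond the scatter). The steps to compound 4 from compound 2 and from compound 3 cannot be read, as both ends of each are limits.

On these data alone, how the fluorophenyl compounds rank against each other stays open. Also open, as far as these compounds go, is whether 4-fluorophenyl or an aminophenyl group would come closer to compound 1.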